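Three Hindered Phenol Amides and a Difluorobenzyl Analogue

A few compounds are considered here, and "the series" means these few. Any claim that something is new, unique, unknown or untested is made for them only; others in the source may bear on it.

Measured compounds:
compound 1, `CC(C)(C)c1cc(CCC(=O)NC2CCN(Cc3ccccc3)CC2)cc(C(C)(C)C)c1O`: 70400 nM
compound 2, `CC(C)(C)c1cc(/C=C/C(=O)NCC2CCN(Cc3ccccc3)CC2)cc(C(C)(C)C)c1O`: 11700 nM
compound 3, `Cc1ccccc1CN1CCC(CCNC(=O)/C=C/c2cc(C(C)(C)C)c(O)c(C(C)(C)C)c2)CC1`: 7200 nM

All three compounds were tested in an assay on isolated protein for inhibition of Amine oxidase [flavin-containing] B (Homo sapiens), read by fluorescence, with stated times of 15 min and 20 min; on this read-out lower numbers stand for stronger inhibition and higher numbers for weaker inhibition. Compound 3 gives 7200 nM, the lowest of the three numbers. Compound 2 stands close by with 11700 nM, and the gap between these two lies within the scatter of repeated measurements, so nothing can be read into their order. Compound 1, with 70400 nM, stands clearly apart, its number beyond the scatter from that of compound 3.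

Compound 4, `CC(C)(C)c1cc(/C=C/C(=O)NCCC2CCN(Cc3ccc(F)c(F)c3)CC2)cc(C(C)(C)C)c1O`, has not yet been measured. It differs from compound 3 in a single place: 3,4-difluorophenyl in place of 2-methylphenyl on a saturated chain carbon bound to an amine nitrogen in a ring. Among the measured compounds shown here, no pair among the measured compounds shows this kind of change, so there is no step to lean on. With nothing comparable in hand, compound 4 is expected to show a step from compound 3 of a 1.1-fold lower number from compound 3 to compound 4 (0.04 log units; within the scatter), that is, nothing beyond the scatter. The estimate for compound 4 is 6500 nM, expected to fall between 2000 nM and 20000 nM.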

Compound 4, half-maximal inhibitory concentration: 9300 nM
Compound 4: the middle estimate sits 1.4-fold (0.16 log units) below what was measured; low and high end bracket the measured number.
By their numbers in this assay, from the lowest: compounds 3, 4 and 2 (each within the scatter of the next); then compound 1.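

In this assay, putting 3,4-difluorophenyl in place of 2-methylphenyl on a saturated chain carbon bound to an amine nitrogen in a ring gives a 1.3-fold higher number from compound 3 to compound 4 (0.11 log units; within the scatter). Among the compounds shown here, this is the first comparison here that changes only one place, and it shows that this position accepts the exchange of a methyl-bearing aromatic ring for a difluorinated one with no change beyond the scatter. No measured evidence speaks to why the two groups read alike.

Going by these compounds, whether a different group here, such as a pyridine ring or a benzyl carrying a carboxylic acid or an amine, would move the number beyond the scatter remains open. Compound 1 differs from the other compounds in more than one place, so its distance from them cannot be assigned to any single change.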